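Benzyl to methoxycarbonyl: notes on a series at the limit

The source may report more compounds than this note shows. Statements on the series, on what has been measured and on what is new or still open speak of the compounds shown alone.

The compounds here share one core. In a functional assay on HT-29 cells (Homo sapiens) for inhibition, read by sulforhodamine B assay (a lower number here means a stronger inhibitor, a higher number a weaker inhibitor), compound 1 (`COC(=O)CC/C(C)=C/Cc1c(OC)c(C)c2c(c1OCC#CCN1CCN(C(c3ccc(F)cc3)c3ccc(F)cc3)CC1)C(=O)OC2`) reads > 50000 nM as a limit of the assay and not a number. Compound 2 (`COC(=O)CC/C(C)=C/Cc1c(OC)c(C)c2c(c1OCC#CCN1CCN(c3ccc(O)cc3)CC1)C(=O)OC2`) reads > 50000 nM as a limit as well. From the compounds shown here alone, compound 3 (`COC(=O)CC/C(C)=C/Cc1c(OC)c(C)c2c(c1OCC#CCN1CCC(Cc3ccccc3)CC1)C(=O)OC2`) reads > 50000 nM as a limit too, so its true position is unknown and nothing ranks it against the other two. Among the measured compounds shown here, the whole set comes down to the limit of > 50000 nM in this assay, at which 3 of the 3 values shown sit, and no measured step exists between any two compounds.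

Compound 4 (`COC(=O)CC/C(C)=C/Cc1c(OC)c(C)c2c(c1OCC#CCN1CCC(C(=O)OC)CC1)C(=O)OC2`) follows from compound 3 with methoxycarbonyl in place of benzyl on a saturated ring carbon. Without a measured step as a guide, no change beyond the scatter is expected in this assay in either direction. The expected step is a number no higher from compound 3 to compound 4 (the limit leaves the size open) and this is a placeholder at the limit rather than a predicted gain or loss. The expectation rests on compound 3 at > 50000 nM as a limit. The estimate for compound 4 is 50000 nM with an expected range from 20000 nM to 100000 nM and a report of only a limit is the likeliest outcome.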

Compound 4, half-maximal inhibitory concentration: > 50000 nM
Compound 4 was reported as a limit; the forecaster's own chance of this, stated with the estimate: 80%; the middle value sits exactly at the limit.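

In this assay compound 4 reads > 50000 nM, a limit of the assay and not a number. Compound 3 also stands at a limit, so no step from compound 3 to compound 4 can be read: the limit of > 50000 nM in this assay, at which 4 of the 4 values shown sit.

The compounds shown leave open how compounds 1 to 4 rank against one another and whether exchanging benzyl for methoxycarbonyl changes inhibition at all.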